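This account rests on a few compounds, and the source may have more. Where it says the series, first, only, none or still open, it means among the compounds named here.

Working notes on the series. Three analogues of the shared core carry a thiocarbonyl bearing a sulfur and an amine; they have been tested in a toxicity assay on HeLa cells (Homo sapiens) for cytotoxicity, read by MTT assay, with a stated time of 24 h; a higher number here means a weaker inhibitor, a lower number a stronger inhibitor. Compound 1 `Cc1ncc([N+](=O)[O-])n1CC(O)CSC(=S)N1CCN(c2ccccc2F)CC1` gives 3240000 nM; compound 2 `Cc1ncc([N+](=O)[O-])n1CC(O)CSC(=S)N1CCCCC1` gives 1400000 nM; compound 3 `Cc1ncc([N+](=O)[O-])n1CC(O)CSC(=S)N1CCC(Cc2ccccc2)CC1` gives 1320000 nM. Compound 2 holds the second highest of the three numbers: its nearest neighbour is compound 3, within the scatter, and its furthest is compound 1, beyond the scatter. Among the measured compounds shown here, the one single-point step among the measured compounds, a 1.1-fold lower number from compound 2 to compound 3 (0.03 log units; within the scatter), shows no effect beyond the scatter.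

Compound 4 `CCN(C)C(=S)SCC(O)Cn1c([N+](=O)[O-])cnc1C` is the next member, not yet measured. Relative to compound 2 the change is ethyl(methyl)amino in place of piperidin-1-yl on a thiocarbonyl carbon. For the measured compounds named here, no measured step tests the exchange of the piperidin-1-yl for an open-chain amine on the thiocarbonyl carbon; the only step recorded at this position, from compound 2 to compound 3, altered a substituent on the ring and stayed within the scatter. With no step beyond the scatter at this part of the molecule, no step beyond the scatter is expected in this assay either, so the expected step from compound 2 to compound 4 is a 1.1-fold higher number from compound 2 to compound 4 (0.06 log units; within the scatter). Compound 4 is therefore estimated at 1600000 nM, with a range from 600000 nM to 4500000 nM.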

Compound 4, half-maximal inhibitory concentration: 4150000 nM
Compound 4: middle estimate off by 2.6-fold (0.41 log units), on the low side, within the range that was stated.
By their numbers in this assay, from the lowest: compounds 3 and 2 (each within the scatter of the next); then compounds 1 and 4 (each within the scatter of the next).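

In this assay, among the compounds shown here, a 3.0-fold higher number from compound 2 to compound 4 (0.47 log units; beyond the scatter) is the only step beyond the scatter at the amine on the thiocarbonyl carbon, so this position does respond to change, and the direction is towards a weaker inhibitor. The earlier step, a 1.1-fold lower number from compound 2 to compound 3 (0.03 log units; within the scatter), altered only a substituent on the ring and kept the piperidin-1-yl in place, whereas here the ring itself is gone, with ethyl(methyl)amino of 4 heavy atoms entering for piperidin-1-yl of 6 heavy atoms. The step is modest, rests on a single pair, and does not separate the loss of the ring from the lower count of heavy atoms, and no measurement at hand offers a reason for the shift.

The compounds shown leave open whether a longer open-chain amine such as dipropylamino would stay with compound 4 or return to the level of compound 2, and whether a smaller ring such as pyrrolidin-1-yl would keep the number of compound 2. Also open, from the compounds shown here alone, is what a hydroxyl or a carboxylic acid on the open chain would do in this assay.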